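The source may report more compounds than this note shows. Statements on the series, on what has been measured and on what is new or still open speak of the compounds shown alone.

Measured so far in an ADME assay on the whole organism with Oryza sativa as the target, tested at 10 uM; on this read-out lower numbers stand for a stronger effect and higher numbers for a weaker effect at the one concentration tested:
- compound 1 `Cc1ccc(NC(=O)N[C@H](C)c2ccccc2)cc1`: 64%
- compound 2 `Cc1ccc(NC(=O)N[C@@H](C)c2ccccc2)cc1`: 100%
- compound 3 `CC(C)c1ccccc1NC(=O)N[C@H](C)c1ccccc1`: 17%

Compound 1 stands second highest of the three numbers. Its nearest neighbour is compound 2, which gives 100%; the step of a number 36 percentage points higher from compound 1 to compound 2 (beyond the scatter) is the only one computed in the set, and it rests on the fact that compounds 1 and 2 differ only in the configuration as drawn alone. Furthest from compound 1 is compound 3, whose 17% is a lower number, but no step between compound 1 and compound 3 has been computed, so only the two values themselves can be compared.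

Compound 4 `CCCCCc1ccc(NC(=O)N[C@H](C)c2ccccc2)cc1` is still to be measured. It differs from compound 1 by butyl in place of hydrogen on a saturated chain carbon bound to an aromatic carbon. Among the compounds with values here, none of the measured steps bears on this change: the one computed step concerns configuration only, and the chain-length change has no measured counterpart. No direction can therefore be drawn from the data; the expectation for compound 4 is a number close to compound 1, with a wide range. Compound 4 is estimated at 55%, between 20% and 90%, which means an expected step of a number 9 percentage points lower from compound 1 to compound 4 (within the scatter).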

Compound 4, a percentage reported as activity, at one concentration (the size of the read-out at that concentration, not a potency): 97%
Compound 4: the middle estimate sits 42 percentage points below what was measured, outside the stated range (above it).
By their numbers in this assay, from the lowest: compound 3; then compound 1; then compounds 4 and 2 (each within the scatter of the next).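

In this assay, butyl in place of hydrogen on a saturated chain carbon bound to an aromatic carbon gives a number 33 percentage points higher from compound 1 to compound 4 (beyond the scatter). Within the data shown here, until now, the only computed step concerned configuration; this one shows that the read-out also responds to a change in the chain at this place, with the higher number standing for a weaker effect at the one concentration tested. Nothing available on the series bears on why the longer chain has this result.

With only methyl and pentyl at this place, the compounds shown leave open whether the number rises gradually with chain length or already reaches this level with a shorter chain such as ethyl or propyl. They also leave open whether a pentyl chain ending in an amine or a carboxylic acid would give a similar number.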